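This account rests on a few compounds, and the source may have more. Where it says the series, first, only, none or still open, it means among the compounds named here.

Measured so far:
Compound 1, `COc1ccc(Cc2coc3cc(O)cc(O)c3c2=O)cc1`, gives > 100000 nM in a functional assay on H9c2 cells (Mus musculus) for cytotoxicity against H9c2 (Rattus norvegicus), read by MTT assay, with a stated time of 24 h; a higher number here means that more compound is needed for the effect, a lower number that less compound is needed; this value is a limit of the assay.
Compound 2, `O=c1c(Cc2ccc(C(F)(F)F)cc2)coc2cc(O)cc(O)c12`, gives 12700 nM in this assay.
Compound 3, `COc1ccc(Cc2coc3cc(OC)cc(OC)c3c2=O)cc1`, gives > 100000 nM in this assay; this value is a limit of the assay.

Compound 3 therefore stands at the limit, not at a number, and it shares that position with compound 1, since (the limit of > 100000 nM in this assay, at which 2 of the 3 values shown sit). Only compound 2 has a measured value in this assay.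

Compound 4, `COc1cc(OC)c2c(=O)c(Cc3ccc(C(F)(F)F)cc3)coc2c1`, differs from compound 3 in one place: trifluoromethyl in place of methoxy on an aromatic carbon.

Going by the values given here, one measured step bears on this change. It is an at least 7.8-fold lower number from compound 1 to compound 2 (0.89 log units; beyond the scatter), the same replacement carried out on the core of compound 1, which bears two hydroxy groups where compound 3 bears two methoxy groups. That step was beyond the scatter and ran toward a lower number, though its size is only known as a lower bound, because compound 1 sits at the limit. A step of at least similar size and the same direction is expected in this assay, expressed as an at least 5.0-fold lower number from compound 3 to compound 4 (0.69 log units; beyond the scatter). Since compound 3 is itself only a limit, the endpoint of that step is uncertain and compound 4 may again return a limit. The estimate for compound 4 is 20000 nM, with a range from 5000 nM to 100000 nM.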

Compound 4, half-maximal effective concentration: > 100000 nM
Compound 4 was reported as a limit; the forecaster's own chance of this, stated with the estimate: 30%; middle value at least 5.0-fold (0.69 log units) from the limit.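

Compound 3 and compound 4 both stand at a limit of the assay, so no step can be read between them: the limit of > 100000 nM in this assay, at which 3 of the 4 values shown sit.

The compounds shown leave open whether trifluoromethyl in place of methoxy changes the number at all on the core of compound 3, and so whether the step seen on the core of compound 1 carries over.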